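This account rests on a few compounds, and the source may have more. Where it says the series, first, only, none or still open, it means among the compounds named here.

Of the compounds shown here, three sharing one core have been measured so far in a functional assay on cells (Tumor Cell line, Homo sapiens) for cytotoxicity (a higher number here means a weaker inhibitor, a lower number a stronger inhibitor), on tumor cells. Compound 1 `CN(C)Cc1cc(C(=O)/C=C/c2ccccc2)cc(CN(C)C)c1O` gives 21900 nM there, compound 2 `CN(C)Cc1cc(C(=O)/C=C/c2ccc(Cl)cc2)cc(CN(C)C)c1O` gives 10000 nM and compound 3 `CN(C)Cc1cc(C(=O)/C=C/c2ccc(Cl)c(Cl)c2)cc(CN(C)C)c1O` gives 2350 nM as the lowest number of the three. Compound 4 `CN(C)Cc1cc(C(=O)/C=C/c2c(F)cccc2Cl)cc(CN(C)C)c1O` is still unmeasured. Relative to compound 3 it puts 2-chloro-6-fluorophenyl in place of 3,4-dichlorophenyl on a double-bonded chain carbon bound to a double-bonded chain carbon, a difference counted as 2-chloro-6-fluorophenyl in place of 3,4-dichlorophenyl on a double-bonded chain carbon bound to a double-bonded chain carbon in full. The bearing steps are modest: a 2.2-fold lower number from compound 1 to compound 2 (0.34 log units; beyond the scatter) with one chloro added, a 4.3-fold lower number from compound 2 to compound 3 (0.63 log units; beyond the scatter) with another, and a 9.3-fold lower number from compound 1 to compound 3 (0.97 log units; beyond the scatter) overall. Among the compounds with values here, no measured compound carries fluoro, so that part of the change is untested. Compound 4 keeps a single chloro, as does compound 2 at 10000 nM for comparison. A modest rise is therefore expected, estimated as a 2.6-fold higher number from compound 3 to compound 4 (0.41 log units; beyond the scatter) in this assay terms. Compound 4 is expected at 6000 nM within an estimated range of 2000 nM to 18000 nM overall.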

Compound 4, half-maximal inhibitory concentration: 9120 nM
Estimate against measurement, compound 4: 1.5-fold (0.18 log units) below, and the stated range covers the measured number.
By their numbers in this assay, from the lowest: compound 3; then compounds 4 and 2 (each within the scatter of the next); then compound 1.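

Replacing 3,4-dichlorophenyl with 2-chloro-6-fluorophenyl on this double-bonded chain carbon loses ground in this assay, with a 3.9-fold higher number from compound 3 to compound 4 (0.59 log units; beyond the scatter) for this change, so a ring with two halogens does not by itself match compound 3. The new ring cannot be told apart from 4-chlorophenyl, with a 1.1-fold lower number from compound 2 to compound 4 (0.04 log units; within the scatter) on that comparison, yet it keeps a gain over plain phenyl, with a 2.4-fold lower number from compound 1 to compound 4 (0.38 log units; beyond the scatter) on that one. Nothing available here accounts for the difference between these halogen patterns.

Open, from the compounds shown here alone, is whether the result for compound 4 follows from the fluoro itself or from where the two halogens stand on the ring. Also open, going by these compounds, is how a methoxy group or a nitrile would read on this ring.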